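Thiophene for phenyl on the aminothiophene ketone series

The compounds below may be only part of what the source reports. "The series", "measured", "known", "first", "only" and "open" are said of these compounds alone.

Measured so far:
compound 1, `COc1cc(C(=O)c2sc(-c3ccccc3)cc2N)cc(OC)c1OC`, 11 nM
compound 2, `COc1cc(C(=O)c2sc(-c3cc(OC)c(OC)c(OC)c3)cc2N)cc(OC)c1OC`, 2300 nM

In a functional assay on L1210 cells (Mus musculus) for antiproliferative activity (a higher number here means a weaker inhibitor, a lower number a stronger inhibitor), compound 1 gives 11 nM, the lowest of the two numbers recorded. Compound 2 gives 2300 nM, a far higher number, and the gap between the two lies well beyond the scatter of repeated runs. For the measured compounds named here, no pair that differs in a single place has been measured, so no single step is yet known in this assay.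

Compound 3, `COc1cc(C(=O)c2sc(-c3cccs3)cc2N)cc(OC)c1OC`, has not been measured. It differs from compound 1 in one place: thiophen-2-yl in place of phenyl on an aromatic carbon. The rest of the shared core is unchanged.

The expectation rests on compound 1 alone, whose value of 11 nM sets the starting point. The step from a six-membered carbon ring to a five-membered ring with one sulfur is expected to be small, not clearly beyond the scatter, as a 1.4-fold higher number from compound 1 to compound 3 (0.13 log units; within the scatter). Compound 3 is therefore estimated at 15 nM, with a range from 4 nM to 60 nM.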

Compound 3, half-maximal inhibitory concentration: 9.8 nM
Compound 3: the middle estimate sits 1.5-fold (0.18 log units) above what was measured; the measured number falls inside the stated range.
By their numbers in this assay, from the lowest: compounds 3 and 1 (each within the scatter of the next); then compound 2.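

In this assay, the position on an aromatic carbon next to the ring sulfur accepts thiophen-2-yl in place of phenyl with a 1.1-fold lower number from compound 1 to compound 3 (0.05 log units; within the scatter). A six-membered aromatic ring of carbon only is therefore not needed here: a five-membered aromatic ring with 1 sulfur serves equally well in this assay, despite having one heavy atom fewer and one hydrogen-bond acceptor more. No measurement is available to explain why the two rings read alike.

Still open, as far as these compounds go, is how far this latitude extends at the same position, for example to furan-2-yl, pyridin-3-yl, cyclohexyl or an open n-butyl chain. Also open, from the compounds shown here alone, is whether the amino group carried by both compound 1 and compound 3 could give way to a hydroxyl or a methyl group with thiophen-2-yl in place.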